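The compounds below may be only part of what the source reports. "The series", "measured", "known", "first", "only" and "open" are said of these compounds alone.

Working notes on the series.

Compound 1 `COc1ccc(S(=O)(=O)Oc2ccccc2/C=C(\C#N)C(=O)Nc2nnc(Cc3ccc(F)cc3)s2)cc1` is the reference point. In a functional assay on HL-60 cells (Homo sapiens) for inhibition, read by CCK-8 assay, with a stated time of 48 h, tested at 20 uM (a lower number here means less inhibition of growth, a higher number more inhibition of growth at the concentration tested), compound 1 gives 100%. Compound 2 `N#C/C(=C\c1ccccc1OS(=O)(=O)c1ccc([N+](=O)[O-])cc1)C(=O)Nc1nnc(Cc2ccc(F)cc2)s1` carries a single change relative to compound 1, (nitro in place of methoxy on an aromatic carbon), and in this assay compound 2 gives 18%. The step is a number 82 percentage points lower from compound 1 to compound 2 (beyond the scatter), the one clear movement in the set so far.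

Compound 3 `COc1ccc(S(=O)(=O)Oc2ccccc2/C=C(\C#N)C(=O)Nc2nnc(Cc3ccc(C)cc3)s2)cc1` differs from compound 1 in the other arm of the molecule, (methyl in place of fluoro on an aromatic carbon), and in this assay compound 3 gives 100%. That step is no change at the digits printed from compound 1 to compound 3 (within the scatter), so the two cores read as equivalent at this concentration.

Compound 4 `Cc1ccc(Cc2nnc(NC(=O)/C(C#N)=C/c3ccccc3OS(=O)(=O)c3ccc([N+](=O)[O-])cc3)s2)cc1` has not been run in this assay. Relative to compound 3 it carries nitro in place of methoxy on an aromatic carbon. Among the compounds with values here, this is the same change as the one from compound 1 to compound 2, at a place described in identical words; the two pairs differ only in their cores, and that difference is the one given by methyl in place of fluoro on an aromatic carbon. With a single precedent and cores that behave alike, the expectation for compound 4 is a drop comparable to the earlier one, estimated as a number 78 percentage points lower from compound 3 to compound 4 (beyond the scatter) beside a number 82 percentage points lower from compound 1 to compound 2 (beyond the scatter), because compound 2 showed a number 82 percentage points lower from compound 1 to compound 2 (beyond the scatter) from a start level matched by compound 3. Compound 4 is thus estimated at 22% in this assay, within a range from 5% to 50%, pending the actual measurement.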

Compound 4, percent growth inhibition at one concentration: 17%
Compound 4: the middle estimate sits 5 percentage points above what was measured, and the stated range covers the measured number.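

On the core of compound 3, nitro in place of methoxy gives a number 83 percentage points lower from compound 3 to compound 4 (beyond the scatter) in this assay, and the size of the step carries over from one core to the other: the same change on two cores in this assay, a number 82 percentage points lower (beyond the scatter) from compound 1 to compound 2 and a number 83 percentage points lower (beyond the scatter) from compound 3 to compound 4, 1 percentage points apart, within the scatter of two such steps

Methyl in place of fluoro, read on the nitro pair, gives a number 1 percentage points lower from compound 2 to compound 4 (within the scatter), and that change stays as quiet there as it was on the methoxy pair: the same change on two cores in this assay, no change at the digits printed (within the scatter) from compound 1 to compound 3 and a number 1 percentage points lower (within the scatter) from compound 2 to compound 4, 1 percentage points apart, within the scatter of two such steps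

This shows that the two changes behave independently across these four compounds, but only for two cores that differ at a single aromatic carbon and at a single tested concentration, so it does not show that the step would hold on a more distant core, why the nitro compounds sit so low, or whether compound 1 and compound 3 would still read alike at a lower concentration.

The compounds shown leave open whether the drop is particular to nitro or also follows from other groups at the same place on the sulfonyl aromatic ring, such as an amine, a chlorine or a trifluoromethyl. They also leave open how far the other arm tolerates change beyond fluoro and methyl, for example a carboxylic acid on that aromatic ring or a longer chain in place of it.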